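Methyl on the aniline ring: expected dog oral bioavailability

The source may report more compounds than this note shows. Statements on the series, on what has been measured and on what is new or still open speak of the compounds shown alone.

Measured so far:
- compound 1, `O=C(CCc1ccc2[nH]c(-c3ccc(Cl)s3)nc2c1)Nc1ccc(N2CCOCC2=O)cc1`, in an in vivo ADME assay on the whole organism for pharmacokinetics, with Canis familiaris (Canis lupus familiaris) as the target (on this read-out higher numbers stand for higher oral bioavailability and lower numbers for lower oral bioavailability), gives < 20%, which is a limit of the assay and not a number.
- compound 2, `O=C(CCc1ccc2[nH]c(-c3ccc(Cl)s3)nc2c1)Nc1ccc(-n2ccccc2=O)c(F)c1`, in this assay gives < 20%, likewise a limit.

Compound 1 therefore stands at the limit of this assay, and no number is known for it. The same holds for compound 2: the limit of < 20% in this assay, at which 2 of the 2 values shown sit. Among the measured compounds shown here, no pair of measured compounds differs in one place, so no measured step is available and nothing can be said about the size or direction of any change beyond the fact that both readings sit at the limit.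

Compound 3, `Cc1cc(NC(=O)CCc2ccc3[nH]c(-c4ccc(Cl)s4)nc3c2)ccc1N1CCOCC1=O`, is not yet measured in this assay. It differs from compound 1 by methyl in place of hydrogen on an aromatic carbon of the ring bearing the 3-oxomorpholin-4-yl group. With both known values at the limit, a step that the limit leaves unreadable from compound 1 to compound 3 is expected, that is, no change beyond the scatter. Compound 3 is estimated at 12%, with a range from 3% to 30%.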

Compound 3, oral bioavailability in the Canis familiaris assay: < 20%
Compound 3: no number, only a limit; the forecaster's own chance of this, stated with the estimate: 65%; the middle value is on the limit's open side.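

Among the compounds shown here, no step from compound 1 to compound 3 can be read, in oral bioavailability or in solubility, as both compounds give only limits. In a physicochemical assay for solubility, in phosphate buffer, at pH 7.0 (on this read-out lower numbers stand for lower solubility and higher numbers for higher solubility), compound 1 gives < 10 ug/mL, a limit and not a number. In the physicochemical assay compound 3 gives < 10 ug/mL, likewise a limit. The compounds shown leave open what size and direction of change, if any, methyl in place of hydrogen on this aromatic carbon brings to either read-out.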